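The source may hold more compounds than are shown below. What is called first, only, known or untested is meant among the compounds shown, and "the series" means these compounds.

Compound 1 `CC(O)(CSc1ccc(C(F)(F)F)cc1)C(=O)Nc1ccc(S(F)(F)(F)(F)F)cc1` is the starting point of this small set. In a functional assay on CWR22R cells (Homo sapiens) for antiproliferative activity, read by propidium iodide staining, with a stated time of 96 h (on this read-out higher numbers stand for weaker inhibition and lower numbers for stronger inhibition), compound 1 gives 14800 nM. Compound 2 `CC(O)(CSc1ccc(OC(F)(F)F)cc1)C(=O)Nc1ccc(S(F)(F)(F)(F)F)cc1` differs from compound 1 in a single spot (trifluoromethoxy in place of trifluoromethyl on an aromatic carbon), and in this assay compound 2 gives 14900 nM. That exchange made a 1.0-fold higher number from compound 1 to compound 2 (0.00 log units; within the scatter), so the two values cannot be told apart here.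

Compound 3 `CC(O)(CSc1ccc(C(F)(F)F)cc1)C(=O)Nc1cccc(S(F)(F)(F)(F)F)c1` is built from the same atoms as compound 1, joined differently; the difference between the two cores is not broken down here. In this assay compound 3 gives 26900 nM. Set against compound 2 and compound 1, the values of compound 3 lie within the usual scatter of them, so no order among the three can be read from these numbers.

Compound 4 `CC(O)(CSc1ccc(OC(F)(F)F)cc1)C(=O)Nc1cccc(S(F)(F)(F)(F)F)c1` has not yet been measured. It differs from compound 3 in one place (trifluoromethoxy in place of trifluoromethyl on an aromatic carbon). This is the same change that leads from compound 1 to compound 2, and it occurs twice among these compounds. Because the earlier instance gave a 1.0-fold higher number from compound 1 to compound 2 (0.00 log units; within the scatter), the step expected from compound 3 to compound 4 is a small one, a 1.0-fold higher number from compound 3 to compound 4 (0.00 log units; within the scatter), which would leave the value roughly where compound 3 stands. On that basis compound 4 is estimated to give 27000 nM in this assay, with a likely range from 13000 nM to 56000 nM. Whether the measurement lands there remains to be seen.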

Compound 4, half-maximal inhibitory concentration: 17000 nM
Beside the measured number, compound 4's estimate is 1.6-fold (0.20 log units) above it, within the range that was stated.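

In this assay, putting trifluoromethoxy in place of trifluoromethyl on the core of compound 3 gave a 1.6-fold lower number from compound 3 to compound 4 (0.20 log units; within the scatter), so this step, like the first one, is too small to count as a real difference. Set side by side, the two steps cannot be told apart, and the exchange looks the same on both cores: the same change on two cores in this assay, a 1.0-fold higher number (0.00 log units; within the scatter) from compound 1 to compound 2 and a 1.6-fold lower number (0.20 log units; within the scatter) from compound 3 to compound 4, 1.6-fold (0.20 log units) apart, within the scatter of two such steps

For these two pairs, then, trifluoromethoxy and trifluoromethyl can be exchanged on either core with no readable effect on the antiproliferative number, but two pairs make no general rule, and nothing here shows how the exchange would behave on any other core or in any other test, or why the two groups give such similar numbers.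

As far as these compounds go, only these two groups appear at this spot on the ring that carries the sulfur, so it remains open whether a group of a different kind there, such as a nitrile, an amine or a carboxylic acid, would move the number beyond the usual scatter. From the compounds shown here alone, it is equally open what a sulfone in place of the sulfur link, or a longer chain between the sulfur and the carbon bearing the hydroxyl, would do.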